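A few compounds are considered here, and "the series" means these few. Any claim that something is new, unique, unknown or untested is made for them only; others in the source may bear on it.

Compound 1 `COc1ncc(-c2ccc3nc(NC(C)=O)nn3c2)cc1NS(=O)(=O)c1ccc(F)cc1` and compound 2 `COc1ncc(-c2ccc3nc(NC(C)=O)nn3c2)cc1NS(=O)(=O)c1ccc(C)cc1` share one core and differ only in the substituent on the sulfonyl-bearing ring. In a functional assay on HCT-116 cells (Homo sapiens) for antiproliferative activity, read by MTT assay, with a stated time of 48 h (on this read-out higher numbers stand for weaker inhibition and lower numbers for stronger inhibition), compound 2 gives 600 nM, while compound 1 gives 850 nM; the change fluoro in place of methyl on an aromatic carbon brings a 1.4-fold higher number from compound 2 to compound 1 (0.15 log units; within the scatter). Compound 3 `COc1ncc(-c2ccn3nc(NC(C)=O)nc3c2)cc1NS(=O)(=O)c1ccc(C)cc1` carries the (4-methylphenyl)sulfonyl group on a different core; the difference between the two cores is not broken down here. In this assay compound 3 gives 1380 nM, a higher number than compound 2 shows, whereas against compound 1 no order can be read. Compound 4 `COc1ncc(-c2ccn3nc(NC(C)=O)nc3c2)cc1NS(=O)(=O)c1ccc(F)cc1` applies to the core of compound 3 the change already seen in the first pair: fluoro in place of methyl on an aromatic carbon. Resting on a 1.4-fold higher number from compound 2 to compound 1 (0.15 log units; within the scatter), the expected step in this assay is a 1.4-fold higher number from compound 3 to compound 4 (0.15 log units; within the scatter). Compound 4 is therefore estimated at 1950 nM, plausibly between 1000 nM and 4000 nM.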

Compound 4, half-maximal inhibitory concentration: 1320 nM
The estimate for compound 4 lay 1.5-fold (0.17 log units) above the measured number, within the range that was stated.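

In this assay, fluoro in place of methyl on an aromatic carbon of the core of compound 3 brings a 1.0-fold lower number from compound 3 to compound 4 (0.02 log units; within the scatter). Set beside the same change on the core of compound 1, the two steps show no difference that can be told from the scatter: the same change on two cores in this assay, a 1.4-fold higher number (0.15 log units; within the scatter) from compound 2 to compound 1 and a 1.0-fold lower number (0.02 log units; within the scatter) from compound 3 to compound 4, 1.5-fold (0.17 log units) apart, within the scatter of two such steps

This shows that the swap from 4-methylphenyl to 4-fluorophenyl reads the same on these two cores, but both steps lie within the scatter, so it does not show that the change has any effect on either core, and two cores give no rule for others.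

From the compounds shown here alone, it stays open whether an amine, a carboxylic acid or a trifluoromethyl group in place of the methyl or fluoro would give a step beyond the scatter, and whether such a step would carry from one core to the other.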